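A few compounds are considered here, and "the series" means these few. Any claim that something is new, unique, unknown or untested is made for them only; others in the source may bear on it.

Of the compounds shown here, two that share one core have been measured so far. Compound 1 `Cc1nc(SCC(=O)Nc2nc(-c3ccc(Cl)cc3)cs2)n(Nc2ccccc2)c1C` is one of them; in a functional assay on ACHN cells (Homo sapiens) for antiproliferative activity, read by sulforhodamine B assay, with a stated time of 48 h (a lower number here means a stronger inhibitor of growth, a higher number a weaker inhibitor of growth), compound 1 gives 3670 nM. Compound 2 `Cc1ccc(Nn2c(SCC(=O)Nc3nc(-c4ccccc4)cs3)nc(C)c2C)cc1` differs from compound 1 in more than one place; in this assay compound 2 gives 4060 nM. The two numbers lie within the scatter of each other, so compound 1 holds the lower of the two numbers without being separated from compound 2 by more than the usual spread of repeated measurements.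

Compound 3 `COc1ccc(Nn2c(SCC(=O)Nc3nc(-c4ccc(Cl)cc4)cs3)nc(C)c2C)cc1` differs from compound 1 in one place only: methoxy in place of hydrogen on an aromatic carbon. Going by the values given here, no pair of measured compounds shows this change by itself, so nothing measured tells how large its effect is. Since compound 1 gives 3670 nM and compound 2 gives 4060 nM, the step of a 1.0-fold lower number from compound 1 to compound 3 (0.02 log units; within the scatter) is expected to stay within the scatter, in no clear direction. For compound 3 the estimated value in this assay is 3500 nM, with a range from 1500 nM to 8500 nM.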

Compound 3, concentration for 50% growth inhibition: 2270 nM
For compound 3 the middle estimate is 1.5-fold (0.19 log units) above the measured one; the range from low to high includes it.
By their numbers in this assay, from the lowest: compounds 3, 1 and 2 (each within the scatter of the next).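

In this assay, methoxy in place of hydrogen on an aromatic carbon of the six-membered ring, para to a large group, gives a 1.6-fold lower number from compound 1 to compound 3 (0.21 log units; within the scatter). Going by these compounds alone, this pair is the first direct reading of the change, and it shows that this place on the ring can carry methoxy, turning anilino into (4-methoxyphenyl)amino, without a step beyond the usual scatter. Nothing available explains this result.

The compounds shown leave open whether an amine, a carboxylic acid or a longer chain such as butoxy at this same place would give a step beyond the scatter. Going by these compounds, the change also stands in one pair only, so whether methoxy gives a similar step when other parts of the molecule differ remains unknown.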